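The source may hold more compounds than are shown below. What is called first, only, known or untested is meant among the compounds shown, and "the series" means these compounds.

Compound 1 (`COc1ncnc2c1c(-c1ccccc1)cn2[C@@H]1O[C@H](CO)[C@@H](O)[C@H]1O`), compound 2 (`CNc1ncnc2c1c(-c1ccoc1)cn2[C@@H]1O[C@H](CO)[C@@H](O)[C@H]1O`) and compound 3 (`Nc1nc(N)c2c(-c3ccco3)cn([C@@H]3O[C@H](CO)[C@@H](O)[C@H]3O)c2n1`) were tested in a functional assay on A549 cells (Homo sapiens), read by MTT assay, with a stated time of 72 h; a lower number here means a stronger inhibitor, a higher number a weaker inhibitor. In this assay, compound 1 gives > 20000 nM, which is a limit of the assay and not a number. Compound 2 gives > 20000 nM, again a limit. Compound 3 gives > 20000 nM, also a limit. Compound 3 therefore has no numeric standing of its own, and the whole set sits at the limit of > 20000 nM in this assay, at which 3 of the 3 values shown sit.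

Compound 4 (`Nc1nc(N)c2c(-c3cccs3)cn([C@@H]3O[C@H](CO)[C@@H](O)[C@H]3O)c2n1`) keeps the core of compound 3 and carries thiophen-2-yl in place of furan-2-yl on an aromatic carbon. Among the measured compounds shown here, no measured pair shows what a single change does here, so the expectation is only a cautious one. With compound 3 at > 20000 nM, no step beyond the scatter is expected in this assay, and a limit is again the likeliest result. For compound 4 the estimated value is 20000 nM, with an expected range from 5000 nM to 40000 nM. The expected step is a number no higher from compound 3 to compound 4 (the limit leaves the size open).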

Compound 4, half-maximal inhibitory concentration: > 20000 nM
Compound 4 was reported as a limit; the forecaster's own chance of this, stated with the estimate: 75%; the middle value lies on the limit itself.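

From the compounds shown here alone, compound 3 and compound 4 both stand at a limit of the assay, so no step can be read between them, and the size of the thiophen-2-yl for furan-2-yl change stays unknown. The compounds shown leave open what any single change on the shared core does, with every value at one limit: the limit of > 20000 nM in this assay, at which 4 of the 4 values shown sit.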